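The compounds below may be only part of what the source reports. "The series", "measured", "known", "first", "only" and "open" are said of these compounds alone.

Measured in an ADME assay on A549 cells (Homo sapiens) for cytotoxicity, read by CellTiter-Glo; a lower number here means that less compound is tolerated, a higher number that more compound is tolerated:
- Compound 1 `Cc1c(Cc2ccccc2)c(=O)oc2cc(OCC(O)CNc3cc([N+](=O)[O-])ccc3O)ccc12`: > 100000 nM, a limit
- Compound 2 `Cc1c(Cc2ccccc2)c(=O)oc2cc(OCC(O)CNc3nc4ccccc4[nH]3)ccc12`: > 100000 nM, a limit
- Compound 3 `Cc1c(Cc2ccc(C(C)(C)C)cc2)c(=O)oc2cc(OCC(O)CN3CCC(C(N)=O)CC3)ccc12`: 14700 nM

Compound 3 is the only one of the three with an actual number, 14700 nM. The other two rest on (the limit of > 100000 nM in this assay, at which 2 of the 3 values shown sit).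

Compound 4 `Cc1c(Cc2ccc(Cl)cc2)c(=O)oc2cc(OCC(O)CN3CCC(C(N)=O)CC3)ccc12` keeps the amine side chain of compound 3 and changes one group: chloro in place of tert-butyl on an aromatic carbon. Put another way, 4-(tert-butyl)benzyl becomes 4-chlorobenzyl.

Within the data shown here, no measured step covers this change. Among the measured compounds shown here, the one step available, a step that the two limits leave unreadable from compound 1 to compound 2, has no readable size and concerns a group on an amine nitrogen, so it offers no guide here.

For the measured compounds named here, the only lean comes from compound 3 itself. Going by the values given here, compound 3 gives 14700 nM, is the one compound with a number, and is also the one carrying tert-butyl. This is weak evidence, since compound 1 and compound 2 also differ from it at the amine.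

The expected step, a 2.2-fold higher number from compound 3 to compound 4 (0.34 log units; beyond the scatter), therefore leans modestly toward more compound tolerated in this assay, though a result within the scatter would be unsurprising. For compound 4 the estimated value is 32000 nM, with an expected range of 12000 nM to 90000 nM.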

Compound 4, half-maximal cytotoxic concentration: 40000 nM
The estimate for compound 4 lay 1.3-fold (0.10 log units) below the measured number; the measured number falls inside the stated range.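

In this assay, the change gives a 2.7-fold higher number from compound 3 to compound 4 (0.43 log units; beyond the scatter), with the amine side chain held the same, so the group on this aromatic carbon of the benzyl group does shift the number. Among these compounds, this is the first step whose size can be read; the earlier step, from compound 1 to compound 2, cannot be read because both of its ends are limits rather than numbers: the limit of > 100000 nM in this assay, at which 2 of the 4 values shown sit. The step also swaps a group of four carbons for a single chlorine, and both compound 3 and compound 4 still give real numbers, so on this amine side chain the assay can follow changes at this place.

On these data alone, one pair gives a single step, not a trend, so it remains open whether a plain hydrogen, a methoxy group or a trifluoromethyl group at this place would fall in line with tert-butyl and chloro. As far as these compounds go, it is equally open whether chloro in place of tert-butyl would give a similar step on a different amine side chain, such as the benzimidazole amine of compound 2.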